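Phenyl in place of methyl on a shared hydrazone core

The source may report more compounds than this note shows. Statements on the series, on what has been measured and on what is new or still open speak of the compounds shown alone.

Compound 1 `COc1ccc(/C=N/Nc2nc(-c3ccccc3)c[se]2)cc1` gives 50500 nM in a functional assay on HepG2 cells (Homo sapiens) for cytotoxicity, read by XTT assay, with a stated time of 72 h; a lower number here means a stronger inhibitor, a higher number a weaker inhibitor.
Compound 2 `CC(=O)N(/N=C/c1ccc(Cl)cc1)c1nc(-c2ccccc2)c[se]1` gives in this assay only a limit, > 62000 nM.
Compound 3 `COc1ccc(/C=N/N(C(C)=O)c2nc(C)c[se]2)cc1` gives in this assay only a limit, > 74300 nM.

Compound 3 therefore stands at a limit of this assay, not at a number, and compound 2 likewise sits at a limit (the limit of > 62000 nM in this assay, at which 1 of the 3 values shown sits, (the limit of > 74300 nM in this assay, at which 1 of the 3 values shown sits)). Compound 4 `COc1ccc(/C=N/N(C(C)=O)c2nc(-c3ccccc3)c[se]2)cc1` differs from compound 3 in one place: phenyl in place of methyl on an aromatic carbon. Going by the values given here, no pair of measured compounds isolates this change, so its size is unknown. Compound 1, which carries the phenyl without the acetyl group, reaches only a weak measurable value. Compound 4 is expected to stay weak, with an estimate of 70000 nM, between 30000 nM and 160000 nM. The step of an at least 1.0-fold lower number from compound 3 to compound 4 (0.02 log units; that floor lies within the scatter) implied by this estimate is expected to lie within the scatter, and a limit rather than a number is likely.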

Compound 4, half-maximal inhibitory concentration: > 62700 nM
Compound 4 ended at the assay's limit; the forecaster's own chance of this, stated with the estimate: 65%; the middle value is on the limit's open side.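

Compound 4 gives > 62700 nM in this assay, which is a limit and not a number. Acetyl in place of hydrogen on the nitrogen gives an at least 1.2-fold higher number from compound 1 to compound 4 (0.09 log units; that floor lies within the scatter), so this one pair cannot say whether the acetyl group changes the result. Going by these compounds, the steps from compound 3 and from compound 2 to compound 4 cannot be read, as both ends of each are limits, and so the effect of phenyl in place of methyl stays unknown.

On these data alone, whether any group at this position gives a clearly lower number remains open. An amine or a longer chain there might behave differently from methyl or phenyl.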